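Exchanging the aryl group: compound 2 to compound 3

The compounds below may be only part of what the source reports. "The series", "measured", "known", "first", "only" and "open" are said of these compounds alone.

Within the data shown here, in a functional assay on G-361 cells (Homo sapiens) for inhibition, with a stated time of 72 h (a higher number here means a weaker inhibitor, a lower number a stronger inhibitor), compound 2 (`NC1CCC(Nc2nc(NCc3ccc(-n4cccn4)cc3)c3ncn(C4CCCC4)c3n2)CC1`) gives 220 nM, the lower of the two numbers so far. Compound 1 (`NC1CCC(Nc2nc(NCc3ccc(-c4ccccc4)cc3)c3ncn(C4CCCC4)c3n2)CC1`) gives 1020 nM. The next structure, compound 3 (`NC1CCC(Nc2nc(NCc3ccc(-c4ccco4)nc3)c3ncn(C4CCCC4)c3n2)CC1`), brings this change: 6-(furan-2-yl)pyridin-3-yl in place of 4-(1H-pyrazol-1-yl)phenyl on a saturated chain carbon bound to a nitrogen on an aromatic ring. In words, 6-(furan-2-yl)pyridin-3-yl stands in place of 4-(1H-pyrazol-1-yl)phenyl on a saturated chain carbon bound to a nitrogen on an aromatic ring. Among the measured compounds shown here, only one measured step bears on it: a 4.6-fold lower number from compound 1 to compound 2 (0.67 log units; beyond the scatter), a modest step with 1H-pyrazol-1-yl in place of phenyl on an aromatic carbon. For the measured compounds named here, that step replaced one aromatic ring, whereas both change here, and no measured compound carries furan or pyridine. It therefore indicates a plausible size but no direction. No shift beyond the scatter is expected: a 1.4-fold higher number from compound 2 to compound 3 (0.13 log units; within the scatter). For compound 3 the expected value is 300 nM, with an estimated range of 100 nM to 900 nM.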

Compound 3, half-maximal inhibitory concentration: 97 nM
For compound 3 the middle estimate is 3.1-fold (0.49 log units) above the measured one, outside the stated range (below it).
By their numbers in this assay, from the lowest: compound 3; then compound 2; then compound 1.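

At this place, on a saturated chain carbon bound to a nitrogen on an aromatic ring, both aromatic rings can be exchanged at once with a further gain in this assay: 6-(furan-2-yl)pyridin-3-yl in place of 4-(1H-pyrazol-1-yl)phenyl gives a 2.3-fold lower number from compound 2 to compound 3 (0.36 log units; beyond the scatter). Against 4-phenylphenyl, the same group gives an 11-fold lower number from compound 1 to compound 3 (1.02 log units; beyond the scatter), and among these three compounds the number falls as the carbon-only aromatic rings give way to rings with hetero atoms. No measurement on hand accounts for these differences.

Both rings change together in the step to compound 3, so the separate shares of the furan and the pyridine remain unresolved. Also open, going by these compounds, is whether a 6-(thiophen-2-yl)pyridin-3-yl group at this place would keep the number as low.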